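Removing the pentafluoroethyl group: compound 3 to compound 4

The compounds below may be only part of what the source reports. "The series", "measured", "known", "first", "only" and "open" are said of these compounds alone.

Compound 3 (`Fc1ccccc1Cc1nc(-c2nc(C(F)(F)C(F)(F)F)n[nH]2)n2ccccc12`) gives 92 mL.min-1.g-1 in an in vitro ADME assay on microsomes from liver (Homo sapiens) for metabolic stability (a higher number here means faster removal of the compound, a lower number slower removal), level at the top of the series with compound 2 (`Fc1ccccc1Cc1nc(-c2nc(C(F)(F)F)n[nH]2)n2ccccc12`) at 72 mL.min-1.g-1. The gap between them is a 1.3-fold higher number from compound 2 to compound 3 (0.11 log units; within the scatter). Compound 1 (`NC(=O)c1n[nH]c(-c2nc(Cc3ccccc3F)c3ccccn23)n1`) gives < 8 mL.min-1.g-1 in this assay, which is a limit of the assay and not a number.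

Compound 4 (`Fc1ccccc1Cc1nc(-c2ncn[nH]2)n2ccccc12`) has hydrogen in place of 1,1,2,2,2-pentafluoroethyl on an aromatic carbon. The steps bearing on this carbon are an at least 9.0-fold higher number from compound 1 to compound 2 (0.95 log units; beyond the scatter) and an at least 11-fold higher number from compound 1 to compound 3 (1.06 log units; beyond the scatter). For the measured compounds named here, both start from carbamoyl, and no measured compound carries hydrogen there. The expected change is a 3.1-fold lower number from compound 3 to compound 4 (0.49 log units; beyond the scatter), towards a lower number, with its size uncertain. Compound 4 is estimated at 30 mL.min-1.g-1, with an expected range of 11 mL.min-1.g-1 to 70 mL.min-1.g-1.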

Compound 4, intrinsic clearance in microsomes: 175 mL.min-1.g-1
Beside the measured number, compound 4's estimate is 5.8-fold (0.77 log units) below it; measured number above the stated range.
By their numbers in this assay, from the lowest: compounds 2, 3 and 4 (each within the scatter of the next, the first and the last beyond it). At a limit, below all of these: compound 1.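

In this assay, hydrogen on this aromatic carbon brings no slowing of removal: the steps are a 1.9-fold higher number from compound 3 to compound 4 (0.28 log units; within the scatter) and a 2.4-fold higher number from compound 2 to compound 4 (0.39 log units; beyond the scatter). Among the four groups at this position, only carbamoyl stands apart, with an at least 21-fold higher number from compound 1 to compound 4 (1.33 log units; beyond the scatter). Compound 1 therefore sets only a bound on that step, as its value is a limit and not a number: the limit of < 8 mL.min-1.g-1 in this assay, at which 1 of the 4 values shown sits.

On these data alone, what separates carbamoyl from hydrogen and the two fluorinated chains stays open. A carboxylic acid, a nitrile or an amine on this carbon would help to narrow it.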